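A few compounds are considered here, and "the series" means these few. Any claim that something is new, unique, unknown or untested is made for them only; others in the source may bear on it.

Three compounds have so far been measured in an assay on CHO-K1 cells for displacement of a labelled ligand from adenosine receptor A1 (Homo sapiens), read by scintillation counting, with a stated time of 60 min; a higher number here means a weaker inhibitor, a lower number a stronger inhibitor:

Compound 1, `Nc1nc(N/N=C/c2ccc3ncccc3c2)nc2c1ncn2[C@@H]1O[C@H](CO)[C@@H](O)[C@H]1O`, gives 9.8 nM.
Compound 2, `Nc1nc(N/N=C/c2cccnc2Cl)nc2c1ncn2[C@@H]1O[C@H](CO)[C@@H](O)[C@H]1O`, gives 4.6 nM.
Compound 3, `CCCOc1ccc(/C=N/Nc2nc(N)c3ncn([C@@H]4O[C@H](CO)[C@@H](O)[C@H]4O)c3n2)cc1`, gives > 10000 nM.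

For compound 3 this value is a limit of the assay and not a number, (the limit of > 10000 nM in this assay, at which 1 of the 3 values shown sits). Compound 3 therefore stands at the weak end of what has been measured, with the two heteroaryl hydrazones well away from it: the step of an at least 1000-fold higher number from compound 1 to compound 3 (3.00 log units; beyond the scatter) and the step of an at least 2100-fold higher number from compound 2 to compound 3 (3.33 log units; beyond the scatter) are both large, while the step of a 2.1-fold lower number from compound 1 to compound 2 (0.33 log units; beyond the scatter) between the two strong binders is modest.

Compound 4, `Nc1nc(N/N=C/c2ccc(-n3ccnc3)cc2)nc2c1ncn2[C@@H]1O[C@H](CO)[C@@H](O)[C@H]1O`, differs from compound 3 in one place: 1H-imidazol-1-yl in place of propoxy on an aromatic carbon. The measured steps that bear on this change are the two large losses leading into compound 3; they show that the 4-propoxyphenyl group on the hydrazone carbon sits at the limit, whereas the quinolin-6-yl of compound 1 and the 2-chloropyridin-3-yl of compound 2 are tolerated well. Whether an imidazolyl-substituted phenyl behaves like the propoxyphenyl or like the heteroaryl groups is not settled by these three compounds. The step of an at least 10-fold lower number from compound 3 to compound 4 (1.00 log units; beyond the scatter) is expected to recover some binding, and compound 4 is estimated at 1000 nM, within a wide range from 30 nM to 10000 nM.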

Compound 4, inhibition constant: > 10000 nM
Compound 4 was reported as a limit; the forecaster's own chance of this, stated with the estimate: 35%; at least 10-fold (1.00 log units) between middle value and limit.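

In this assay compound 4 gives > 10000 nM, a limit of the assay and not a number, and it is the second compound to end there: the limit of > 10000 nM in this assay, at which 2 of the 4 values shown sit. The step from compound 3 to compound 4 cannot be read, so putting 1H-imidazol-1-yl in place of propoxy brings no recovery of binding that these values can detect. Against the two strong binders the loss is again large, with an at least 2100-fold higher number from compound 2 to compound 4 (3.33 log units; beyond the scatter) and an at least 1000-fold higher number from compound 1 to compound 4 (3.00 log units; beyond the scatter), so two quite different groups on this phenyl ring, propoxy and 1H-imidazol-1-yl, now end at the limit, while the quinolin-6-yl of compound 1 and the 2-chloropyridin-3-yl of compound 2 do not.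

The compounds shown leave open how far past the limit compound 3 and compound 4 lie, and whether they differ from each other at all. They also leave open whether a smaller group in the same place, such as methoxy or a fluorine atom, or a plain phenyl with no group there, would give a measurable value.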